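Inactive amide series: expectation for compound 4

This account rests on a few compounds, and the source may have more. Where it says the series, first, only, none or still open, it means among the compounds named here.

Measured so far, in an assay on isolated protein for inhibition of thyroid hormone receptor alpha (Homo sapiens), read by fluorescence polarization; on this read-out lower numbers stand for stronger inhibition and higher numbers for weaker inhibition:
- compound 1, `CS(=O)(=O)c1ccc(C(=O)N2CCC(C(=O)N(Cc3ccccc3)c3ccccc3)CC2)cc1[N+](=O)[O-]`: compound 1 reaches only the assay limit > 60000 nM.
- compound 2, `CN(Cc1cccc(F)c1)C(=O)CCCNC(=O)c1ccc(S(C)(=O)=O)c([N+](=O)[O-])c1`: compound 2 reaches only the assay limit > 60000 nM.
- compound 3, `CN(Cc1cccc(F)c1)C(=O)CNC(=O)c1ccc(S(C)(=O)=O)c([N+](=O)[O-])c1`: compound 3 reaches only the assay limit > 60000 nM.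

None of the three gives a number in this assay; each reading is a limit. Compound 2 therefore stands where the whole measured set stands, at the limit, and no ordering among compound 1, compound 2 and compound 3 can be read from these values. This is summed up in the limit of > 60000 nM in this assay, at which 3 of the 3 values shown sit.

Compound 4, `CS(=O)(=O)c1ccc(C(=O)NCCCC(=O)N2CCCCC2)cc1[N+](=O)[O-]`, is not yet measured in this assay. It departs from compound 2 by piperidin-1-yl in place of (3-fluorobenzyl)(methyl)amino on a carbonyl carbon; in words, piperidin-1-yl in place of (3-fluorobenzyl)(methyl)amino on a carbonyl carbon. Within the data shown here, no step between measured compounds is available, so the size of this change cannot be read from the series itself.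

Given that compound 2 sits at the limit, and that the other measured compounds also sit there, the change in compound 4 is expected to shift nothing beyond the scatter; the expected step from compound 2 to compound 4 is a step that the limit leaves unreadable from compound 2 to compound 4. Compound 4 is accordingly estimated at 80000 nM in this assay, within a range from 30000 nM to 300000 nM, most likely reported again only as a limit.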

Compound 4, half-maximal inhibitory concentration: > 60000 nM
Compound 4 gave a limit, no number; the forecaster's own chance of this, stated with the estimate: 85%; the middle value lies beyond the limit too.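

Compound 2 and compound 4 each give only a limit, so no step between them can be read: the limit of > 60000 nM in this assay, at which 4 of the 4 values shown sit.

The compounds shown leave open whether piperidin-1-yl or (3-fluorobenzyl)(methyl)amino on a carbonyl carbon makes any difference in this assay, and what change to this series, if any, would yield a measurable value there.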